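This account rests on a few compounds, and the source may have more. Where it says the series, first, only, none or still open, it means among the compounds named here.

Measured compounds:
compound 1 `CC[C@@H](Nc1c(C#N)c(-c2ccc(-c3ncccc3C)cc2)nc2cnccc12)C(N)=O` gives 2
compound 2 `CCOc1ccccc1-c1ccc(-c2nc3cnccc3c(NC(C(N)=O)C3CC3)c2C#N)cc1` gives 3
compound 3 `CC[C@@H](Nc1c(C#N)c(-c2ccc(-c3ccccc3N(C)C)cc2)nc2cnccc12)C(N)=O` gives 3.2

In a physicochemical assay for lipophilicity, read by HPLC, at pH 7.5 (a lower number here means a more polar compound, a higher number a more lipophilic compound), compound 2 stands second highest of the three. Its nearest neighbour is compound 3, within the scatter, and its furthest is compound 1, beyond the scatter. Among the measured compounds shown here, the only measured step, a number 1.20 log units higher from compound 1 to compound 3 (beyond the scatter), changes an aromatic substituent and does not touch the place altered here. Compound 4 `CCOc1ccccc1-c1ccc(-c2nc3cnccc3c(N[C@H](CC)C(=O)O)c2C#N)cc1` differs from compound 2 by a group of 6 heavy atoms (4 carbon, 2 oxygen; no ring) in place of a group of 7 heavy atoms (5 carbon, 1 nitrogen, 1 oxygen; one three-membered non-aromatic ring of carbon only), on a nitrogen on an aromatic ring. For the measured compounds named here, no measured step covers this change, so the expectation rests on the structural description alone. The account expects a fall in this assay for compound 4, an estimated step of a number 2.00 log units lower from compound 2 to compound 4 (beyond the scatter). Compound 4 is therefore estimated at 1, within a range from 0 to 2.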

Compound 4, distribution coefficient: 2.1
The estimate for compound 4 lay 1.10 log units below the measured number, outside the stated range (above it).
By their numbers in this assay, from the lowest: compounds 1 and 4 (each within the scatter of the next); then compounds 2 and 3 (each within the scatter of the next).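

In this assay, 1-carboxypropyl on the nitrogen on an aromatic ring, in place of the group carrying the three-membered ring, gives a number 0.90 log units lower from compound 2 to compound 4 (beyond the scatter). This place, like the aromatic substituent changed in a number 1.20 log units higher from compound 1 to compound 3 (beyond the scatter), can therefore move the number beyond the scatter. Nothing given here explains the step.

The single change both removes the three-membered ring and brings in the carboxylic acid, so the compounds shown cannot separate the two. They also leave open how an amine or a longer chain at this nitrogen would read in this assay.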